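A Fluorophenyl Takes the Place of a Chlorophenyl

The source may hold more compounds than are shown below. What is called first, only, known or untested is meant among the compounds shown, and "the series" means these compounds.

Compound 1 `CC(C)(C)c1ccc(-n2nc(-c3ccc(C(F)(F)F)cc3O)nc2-c2ccccc2O)cc1`: 67.3% in a functional assay on PC-12 cells (Rattus norvegicus) for cytotoxicity, read by MTT assay, with stated times of 2 h and 24 h, tested at 1 uM; a lower number here means a weaker effect, a higher number a stronger effect of the compound at the concentration tested
Compound 2 `Oc1cc(C(F)(F)F)ccc1-c1nc(-c2ccccc2O)n(-c2ccc(OC(F)(F)F)cc2)n1`: 65.5% in this assay
Compound 3 `Oc1cc(C(F)(F)F)ccc1-c1nc(-c2ccccc2O)n(-c2ccccc2Cl)n1`: 70.1% in this assay

Three measured compounds share one core and differ only in the aromatic group carried on a ring nitrogen. Compound 3 has the highest of the three numbers in this assay, yet its lead is small: compound 1 lies a number 2.8 percentage points higher from compound 1 to compound 3 (within the scatter) and compound 2 lies a number 4.6 percentage points higher from compound 2 to compound 3 (within the scatter), both inside the scatter, so no ordering can be claimed among them. The remaining measured step, a number 1.8 percentage points lower from compound 1 to compound 2 (within the scatter), is likewise within the scatter.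

Compound 4 `Oc1cc(C(F)(F)F)ccc1-c1nc(-c2ccccc2O)n(-c2cccc(F)c2)n1` is the next member. Against compound 3 the change is 3-fluorophenyl in place of 2-chlorophenyl on an aromatic nitrogen.

All three measured steps bear on this change, since each swaps the aromatic group on the same nitrogen, and each stayed within the scatter. On that evidence the expected step of a number 2.1 percentage points lower from compound 3 to compound 4 (within the scatter) is none beyond the scatter. Compound 4 is therefore estimated at 68% in this assay, with a range from 58% to 78%.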

Compound 4, a percentage reported as activity, at one concentration (the size of the read-out at that concentration, not a potency): 67.2%
Beside the measured number, compound 4's estimate is 0.8 percentage points above it, and the stated range covers the measured number.
By their numbers in this assay, from the lowest: compounds 2, 4, 1 and 3 (each within the scatter of the next).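

The step from 2-chlorophenyl to 3-fluorophenyl on the aromatic nitrogen changes both the halogen and where it sits on the phenyl ring, yet this assay shows only a number 2.9 percentage points lower from compound 3 to compound 4 (within the scatter). Compared with the other two groups at this nitrogen, the result is the same: 4-(trifluoromethoxy)phenyl gives a number 1.7 percentage points higher from compound 2 to compound 4 (within the scatter), and 4-(tert-butyl)phenyl gives a number 0.1 percentage points lower from compound 1 to compound 4 (within the scatter). All six steps among the four compounds now lie within the scatter, so these four different aromatic groups, with chlorine, fluorine or no halogen directly on the ring, cannot be told apart at this single concentration.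

No measurement of any property of these groups accompanies the numbers, so nothing can be said about what lies behind them. Every group shown on this nitrogen is a six-membered aromatic ring of carbon only, so it remains open whether an amine, a carboxylic acid or a longer alkyl chain in that place would move the number beyond the scatter.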